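The compounds below may be only part of what the source reports. "The series", "measured", "known", "first", "only" and "open" are said of these compounds alone.

Compound 1 `COc1ccc(C2=C(c3cc(OC)c(OC)c(OC)c3)C(=O)CC2O[SiH2]C(C)(C)C)cc1OC` was tested in an ADME assay on L132 cells (Homo sapiens) for cytotoxicity, read by MTT assay, with a stated time of 72 h; a lower number here means a stronger inhibitor, a higher number a weaker inhibitor. There compound 1 gives > 100 ug/mL, which is a limit of the assay and not a number. Compound 2 `COc1ccc(C2=C(c3cc(OC)c(OC)c(OC)c3)CC(O[SiH2]C(C)(C)C)C2=O)cc1[N+](=O)[O-]` likewise stops at a limit in this assay, > 100 ug/mL. Compound 3 `COc1cc(C2=C(c3cc(C)c(OC)c(C)c3)C(OC(C)=O)CC2=O)cc(OC)c1OC` also reaches only a limit in this assay, > 100 ug/mL. Among the measured compounds shown here, compound 1 thus stands exactly where every measured compound stands, at the limit of > 100 ug/mL in this assay, at which 3 of the 3 values shown sit, with no number to set it apart from the others and no step between measured compounds to draw on.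

Compound 4 `COc1ccc(C2=C(c3cc(OC)c(OC)c(OC)c3)C(=O)CC2O[SiH2]C(C)(C)C)cc1` has not yet been measured in this assay. It differs from compound 1 in one place: hydrogen in place of methoxy on an aromatic carbon. Cut one bond further out, the change reads 3,4-dimethoxyphenyl to 4-methoxyphenyl. With all three measured values sitting at the same limit, no step beyond the usual scatter is expected in this assay, and the step is estimated at a step that the limit leaves unreadable from compound 1 to compound 4. Compound 4 is therefore expected to give about 120 ug/mL in this assay, within a range from 50 ug/mL to 300 ug/mL, and most likely to be reported again only as a limit.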

Compound 4, half-maximal inhibitory concentration: > 100 ug/mL
Compound 4: no number, only a limit (the forecaster's own chance of this, stated with the estimate: 80%); the middle value is on the limit's open side.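

No step can be read between compound 1 and compound 4, as both stop at a limit of the assay: the limit of > 100 ug/mL in this assay, at which 4 of the 4 values shown sit.

The compounds shown leave open how far any of them lies from that limit, and whether replacing 3,4-dimethoxyphenyl with 4-methoxyphenyl makes any difference at all.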